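Paired substitution on a triazole nitrogen across two closely related cores

A few compounds are considered here, and "the series" means these few. Any claim that something is new, unique, unknown or untested is made for them only; others in the source may bear on it.

Compound 1 `O=C1Nc2ccccc2/C1=C/c1ccc(-c2cn(-c3ccc(Cl)cc3)nn2)cc1` and compound 2 `N#Cc1ccccc1-n1cc(-c2ccc(/C=C3\C(=O)Nc4ccccc43)cc2)nn1` share one core, and compound 3 `O=C1Nc2ccc(F)cc2C1=Cc1ccc(-c2cn(-c3ccc(Cl)cc3)nn2)cc1` carries a second core that bears a fluorine; how the two cores differ is not broken down here. In a functional assay on MKN-45 cells (Homo sapiens) for inhibition, read by CCK-8 assay, with a stated time of 24 h (on this read-out higher numbers stand for weaker inhibition and lower numbers for stronger inhibition), compound 1 gives 16200 nM. In this assay compound 2 gives 14600 nM, and in this assay compound 3 gives 15800 nM. All three numbers sit close together, and none of them can be set apart from the others.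

The change from compound 1 to compound 2 is 2-cyanophenyl in place of 4-chlorophenyl on an aromatic nitrogen. It made a step of a 1.1-fold lower number from compound 1 to compound 2 (0.05 log units; within the scatter).

Compound 4 `N#Cc1ccccc1-n1cc(-c2ccc(C=C3C(=O)Nc4ccc(F)cc43)cc2)nn1` is not yet measured. It arises from compound 3 by 2-cyanophenyl in place of 4-chlorophenyl on an aromatic nitrogen, the same change that leads from compound 1 to compound 2, placed in the same surroundings on the ring. Because the step of a 1.1-fold lower number from compound 1 to compound 2 (0.05 log units; within the scatter) stayed within the usual scatter, the account expects the matching step on the second core to be small as well. The expected step is a 1.1-fold lower number from compound 3 to compound 4 (0.04 log units; within the scatter). Going by the values given here, for compound 4 the estimated value in this assay is 14500 nM, with a range from 7000 nM to 30000 nM; this estimate rests on the single earlier instance of the change and on the closeness of the three measured values, so it carries the full uncertainty of one precedent.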

Compound 4, half-maximal inhibitory concentration: 15200 nM
Beside the measured number, compound 4's estimate is 1.0-fold (0.02 log units) below it; the range from low to high includes it.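

On the fluorine-bearing core, 2-cyanophenyl in place of 4-chlorophenyl on the aromatic nitrogen gives, in this assay, a 1.0-fold lower number from compound 3 to compound 4 (0.02 log units; within the scatter), so this step, like the earlier one on the core of compound 1, cannot be told apart from repeat-measurement noise. Set side by side, the two steps do not differ, and on these two cores the change carries over as a step too small to read: the same change on two cores in this assay, a 1.1-fold lower number (0.05 log units; within the scatter) from compound 1 to compound 2 and a 1.0-fold lower number (0.02 log units; within the scatter) from compound 3 to compound 4, 1.1-fold (0.03 log units) apart, within the scatter of two such steps. Going by these compounds alone, this agreement rests on one pair of compounds per core and a single read-out, and since neither step stands out from the scatter, it shows only that the change stayed small on both cores, not that a step of real size would transfer from one core to the other or that the same would hold on any further core.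

The compounds shown leave open whether any other group on that aromatic nitrogen, such as a phenyl ring bearing a carboxylic acid or an amine, or a longer alkyl chain in place of the phenyl ring, would move the number beyond the scatter on either core. They also leave open whether the close agreement among these four compounds would persist in other cell lines or at other exposure times.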